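Adding an Ester Group to the Strongest Chroman Amide

The source may report more compounds than this note shows. Statements on the series, on what has been measured and on what is new or still open speak of the compounds shown alone.

Of the compounds shown here, two have been measured so far in a functional assay, with a stated time of 30 min, tested at 100 uM; a lower number here means a weaker effect, a higher number a stronger effect of the compound at the concentration tested. Compound 1, with the structure `CCOC(=O)C(CS)NC(=O)c1cc(C(C)(C)C)c(O)c(C(C)(C)C)c1`, gives 46% in this assay. Compound 2, with the structure `Cc1c(C)c2c(c(C)c1O)CCC(C)(C(=O)NCCS)O2`, gives 92% in this assay, which is the highest of the two numbers; its nearest neighbour is compound 1, whose number lies lower by a gap that is beyond the usual scatter. Among the compounds with values here, the two compounds differ in more than one place, so their pair shows only that the two values stand far apart.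

Compound 3, with the structure `CCOC(=O)C(CS)NC(=O)C1(C)CCc2c(C)c(O)c(C)c(C)c2O1`, has not yet been measured. It differs from compound 2 in a single spot: ethoxycarbonyl in place of hydrogen on a saturated chain carbon bound to an amide-type nitrogen and a saturated chain carbon. Compound 1 already carries this ethoxycarbonyl group, but on a different core, so nothing here isolates what the group alone does.

The step from compound 2 to compound 3 in this assay is therefore uncertain; a modest decrease is expected, a number 12 percentage points lower from compound 2 to compound 3 (beyond the scatter), close to the edge of the scatter. Compound 3 is expected to give about 80% in this assay, in a range from 55% to 97%.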

Compound 3, a percentage reported as activity, at one concentration (the size of the read-out at that concentration, not a potency): 91%
For compound 3 the middle estimate is 11 percentage points below the measured one; measured number inside the range.
By their numbers in this assay, from the lowest: compound 1; then compounds 3 and 2 (each within the scatter of the next).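

In this assay, ethoxycarbonyl in place of hydrogen on a saturated chain carbon bound to an amide-type nitrogen and a saturated chain carbon gives a number 1 percentage points lower from compound 2 to compound 3 (within the scatter), so on this shared core the two compounds cannot be told apart. Within the data shown here, this is the first direct view of the group alone: the 2-sulfanylethyl chain of compound 2 can become the 1-(ethoxycarbonyl)-2-sulfanylethyl chain of compound 3 with no effect that stands clear of the scatter, although the read-out comes from one concentration, so the two compounds could still differ in the size of their effect at other concentrations. Nothing among the data shown offers an explanation for this result.

From the compounds shown here alone, whether a carboxylic acid, an amine or a longer chain at this same carbon would read the same as ethoxycarbonyl remains open. Also open is what ethoxycarbonyl does on the core of compound 1, since no compound shown pairs with compound 1 by a single difference, and the result for the shared core cannot simply be carried over to it.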